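The source may hold more compounds than are shown below. What is called first, only, known or untested is meant among the compounds shown, and "the series" means these compounds.

Measured in a functional assay on BT-483 cells (Homo sapiens) for cytotoxicity, read by MTT assay, with a stated time of 24 h; on this read-out lower numbers stand for stronger inhibition and higher numbers for weaker inhibition:
Compound 1 `CCNc1cc(-c2ccc(NC(=O)Nc3ccc(OC)cc3)cc2C)ccn1`: 25800 nM
Compound 2 `CCNc1cc(-c2ccc(NC(=O)Nc3ccc(C(F)(F)F)cc3)cc2C)ccn1`: 19700 nM

Compound 1 stands within the scatter of compound 2, so neither number sets it apart. Compound 3 `CCNc1cc(-c2ccc(NC(=O)Nc3ccc(OC)cc3)cc2F)ccn1` differs from compound 1 as follows: fluoro in place of methyl on an aromatic carbon. This is fluoro in place of methyl on an aromatic carbon. For the measured compounds named here, the only measured step, a 1.3-fold lower number from compound 1 to compound 2 (0.12 log units; within the scatter), is trifluoromethyl in place of methoxy, at a different place, so it gives no direct reading of this change. No step beyond the scatter is expected in this assay. The expected step is a 1.0-fold lower number from compound 1 to compound 3 (0.01 log units; within the scatter). Compound 3 is estimated at 25000 nM, with an expected range of 13000 nM to 48000 nM.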

Compound 3, half-maximal inhibitory concentration: 19600 nM
The estimate for compound 3 lay 1.3-fold (0.11 log units) above the measured number; the measured number falls inside the stated range.
By their numbers in this assay, from the lowest: compounds 3, 2 and 1 (each within the scatter of the next).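

In this assay the position ortho to the 2-(ethylamino)pyridin-4-yl group gets its first reading: fluoro in place of methyl gives a 1.3-fold lower number from compound 1 to compound 3 (0.12 log units; within the scatter) on this aromatic carbon. For the compounds shown here, the earlier step concerned only trifluoromethyl in place of methoxy at a different place, so this is the first sign that the number tolerates this swap here. No supporting data bear on why this is so. Open, going by these compounds, is whether an amine or a carboxylic acid at this position would shift the number beyond the scatter. On these data alone, a longer chain in place of the ethyl of the ethylamino group also remains untested in these compounds.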